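Benzyl variation on the shared nucleoside core: compound 4

The source may report more compounds than this note shows. Statements on the series, on what has been measured and on what is new or still open speak of the compounds shown alone.

Only the benzyl group on a saturated chain carbon bound to a nitrogen on an aromatic ring varies across this small set. Compound 1 `OC[C@H]1O[C@@H](n2cnc3c(NCc4ccccc4Cl)ncnc32)[C@H](O)[C@@H]1O` gives 64000 nM in a functional assay on K562 cells (Homo sapiens) for antiproliferative activity, with a stated time of 72 h; a higher number here means a weaker inhibitor, a lower number a stronger inhibitor. Compound 2 `OC[C@H]1O[C@@H](n2cnc3c(NCc4ccc(Br)cc4)ncnc32)[C@H](O)[C@@H]1O` gives 68200 nM in this assay, and the step of a 1.1-fold higher number from compound 1 to compound 2 (0.03 log units; within the scatter) stays within the scatter. For compound 3 `COc1cc(CNc2ncnc3c2ncn3[C@@H]2O[C@H](CO)[C@@H](O)[C@H]2O)cc(OC)c1` the result in this assay is only a limit, > 166000 nM. Compound 3 therefore sits at the weak end of what has been measured, separated from compound 1 by an at least 2.5-fold higher number from compound 1 to compound 3 (0.41 log units; beyond the scatter) and from compound 2 by an at least 2.4-fold higher number from compound 2 to compound 3 (0.38 log units; beyond the scatter); what is known of it is the limit (the limit of > 166000 nM in this assay, at which 1 of the 3 values shown sits), not a number.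

Compound 4 `Cc1cccc(CNc2ncnc3c2ncn3[C@@H]2O[C@H](CO)[C@@H](O)[C@H]2O)c1O` has not yet been measured in this assay. It differs from compound 3 by 2-hydroxy-3-methylphenyl in place of 3,5-dimethoxyphenyl on a saturated chain carbon bound to a nitrogen on an aromatic ring. Among the compounds with values here, the steps that bear on this position, an at least 2.5-fold higher number from compound 1 to compound 3 (0.41 log units; beyond the scatter) and an at least 2.4-fold higher number from compound 2 to compound 3 (0.38 log units; beyond the scatter), both show that exchanging the 3,5-dimethoxyphenyl for another substituted phenyl gave a lower number, though neither of those steps starts from a known value. Within the data shown here, no measured compound carries a 2-hydroxy-3-methylphenyl, so the size of the step is uncertain. Compound 4 is expected to give about 110000 nM in this assay, with a range from 50000 nM to 200000 nM. This estimate means a step of an at least 1.5-fold lower number from compound 3 to compound 4 (0.17 log units; that floor lies within the scatter) is expected, back toward the numbers of compounds 1 and 2, though a second limit cannot be ruled out.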

Compound 4, half-maximal inhibitory concentration: 18000 nM
Compound 4: middle estimate off by 6.1-fold (0.79 log units), on the high side; the whole stated range lies above it.
By their numbers in this assay, from the lowest: compound 4; then compounds 1 and 2 (each within the scatter of the next). At a limit, above all of these: compound 3.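

Within the data shown here, the benzyl position can move the number down as well as up: until now, the substituted phenyl groups gave only two values within the scatter of each other and one limit, whereas the 2-hydroxy-3-methylphenyl group gives a 3.6-fold lower number from compound 1 to compound 4 (0.55 log units; beyond the scatter) and a 3.8-fold lower number from compound 2 to compound 4 (0.58 log units; beyond the scatter) in this assay, both modest but beyond the scatter. Against the 3,5-dimethoxyphenyl group the change is larger, with an at least 9.2-fold lower number from compound 3 to compound 4 (0.96 log units; beyond the scatter) as the 2-hydroxy-3-methylphenyl group, with 1 hydrogen-bond donor, replaces a group with 0 hydrogen-bond donors, although this pair alone ties the result to no single feature. Compound 3 is held only as a limit, so the true size of that step stays a floor: the limit of > 166000 nM in this assay, at which 1 of the 4 values shown sits.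

The hydroxyl and the methyl enter together here, so the shift cannot be assigned to either one, and a phenyl carrying the hydroxyl alone or the methyl alone would separate them. From the compounds shown here alone, whether an amine or a carboxylic acid in place of the hydroxyl would keep, extend or lose the shift also remains open.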